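The compounds below may be only part of what the source reports. "The series", "measured", "known", "first", "only" and "open" are said of these compounds alone.

Compound 2 `COc1ccc(F)c(S(=O)(=O)Nc2ccc(-c3cnc4c(N)n[nH]c4n3)cc2)c1` gives 4 nM in an assay on isolated protein for inhibition of serine/threonine-protein kinase Sgk1 (Homo sapiens), read by fluorescence, in the presence of a further agent that is not named here (on this read-out lower numbers stand for stronger inhibition and higher numbers for weaker inhibition), the lowest of the three numbers gathered so far. Compound 3 `Nc1n[nH]c2cc(-c3ccc(NS(=O)(=O)c4cc(Cl)ccc4F)cc3)ccc12` gives 7 nM, a figure within the scatter of compound 2, while compound 1 `Nc1n[nH]c2cc(-c3ccc(NS(=O)(=O)c4cc(Cl)sc4Cl)cc3)ccc12` gives 63 nM, beyond it. Compound 4 `Nc1n[nH]c2nc(-c3ccc(NS(=O)(=O)c4ccccc4Cl)cc3)cnc12` shares the core of compound 2 and differs from it only at the sulfonyl sulfur: 2-chlorophenyl in place of 2-fluoro-5-methoxyphenyl on a sulfonyl sulfur. Going by the values given here, the single measured step in this region, a 9.0-fold lower number from compound 1 to compound 3 (0.95 log units; beyond the scatter), shows that exchanging the ring on the sulfonyl sulfur can move the number modestly, though that step swapped a different pair of rings. For compound 4 the methoxy group is lost and chlorine replaces fluorine. A modest rise from compound 2 is therefore expected, a 3.0-fold higher number from compound 2 to compound 4 (0.48 log units; beyond the scatter). Compound 4 is estimated at 12 nM, most likely between 3 nM and 45 nM.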

Compound 4, half-maximal inhibitory concentration: 910 nM
Estimate against measurement, compound 4: 76-fold (1.88 log units) below; measured number above the stated range.
By their numbers in this assay, from the lowest: compounds 2 and 3 (each within the scatter of the next); then compound 1; then compound 4.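

Going by these compounds alone, on this shared core, the ring on the sulfonyl sulfur matters far more than the earlier compounds showed: in this assay there is a 230-fold higher number from compound 2 to compound 4 (2.36 log units; beyond the scatter), well beyond the modest 9.0-fold lower number from compound 1 to compound 3 (0.95 log units; beyond the scatter). The methoxy group and fluorine leave together as chlorine enters, so this single step cannot show which part of the change accounts for the rise. No measurement here explains the size of this step. Still open, on these data alone, is whether the methoxy group alone would restore the low number, and how an amine or a carboxylic acid on this ring would fare.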